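Pyrazole substituent change on the best compound so far

This account rests on a few compounds, and the source may have more. Where it says the series, first, only, none or still open, it means among the compounds named here.

Compound 3 `C[C@@H]1CN(c2sc(C(F)(F)F)nc2-c2nc3ccccc3[nH]2)CCN1C(=O)Cn1cc(Cl)cn1` stands lowest of the three numbers obtained so far in a functional assay on Venous blood for antagonist activity at C-X-C chemokine receptor type 3 (Homo sapiens), read by flow cytometry, with a stated time of 30 min, in the presence of a further agent that is not named here (a higher number here means a weaker inhibitor, a lower number a stronger inhibitor), at 251 nM. Compound 2 `C[C@@H]1CN(c2sc(C(F)(F)F)nc2-c2nc3ccccc3[nH]2)CCN1C(=O)CN1C(=O)OC[C@@H]1c1ccccc1` gives 1380 nM in this assay, and compound 1 `COC1CCN(CC(=O)N2CCN(c3sc(C(F)(F)F)nc3-c3nc4ccccc4[nH]3)C[C@H]2C)C1` gives 3380 nM. Both steps down to compound 3 lie beyond the scatter: a 13-fold lower number from compound 1 to compound 3 (1.13 log units; beyond the scatter) and a 5.5-fold lower number from compound 2 to compound 3 (0.74 log units; beyond the scatter). The remaining step, a 2.4-fold lower number from compound 1 to compound 2 (0.39 log units; beyond the scatter), is modest.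

Compound 4 `C[C@@H]1CN(c2sc(C(F)(F)F)nc2-c2nc3ccccc3[nH]2)CCN1C(=O)Cn1cc(C2CCN(C)CC2)cn1` differs from compound 3 by 1-methylpiperidin-4-yl in place of chloro on an aromatic carbon. Among the measured compounds shown here, none of the measured steps bears directly on this change: each of them exchanges the whole group on the saturated chain carbon bound to the carbonyl carbon, whereas here the pyrazole ring of compound 3 is kept and only the group on its aromatic carbon is altered. The measured steps show that what sits on that chain carbon can move the number by large amounts, so a change on the pyrazole may also matter, but nothing measured tells the direction. The expectation is therefore a step from compound 3 to compound 4 of no clear size beyond the scatter, a 1.0-fold lower number from compound 3 to compound 4 (0.00 log units; within the scatter), with a wide range on either side. Compound 4 is estimated at 250 nM in this assay, between 80 nM and 800 nM.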

Compound 4, half-maximal inhibitory concentration: 1690 nM
Compound 4: the middle estimate sits 6.8-fold (0.83 log units) below what was measured; measured number outside the range, above it.
By their numbers in this assay, from the lowest: compound 3; then compounds 2, 4 and 1 (each within the scatter of the next, the first and the last beyond it).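

In this assay, among the compounds shown here, the aromatic carbon of the pyrazole proves responsive on its own: with the ring kept and 1-methylpiperidin-4-yl in place of chloro, the result is a 6.7-fold higher number from compound 3 to compound 4 (0.83 log units; beyond the scatter), whereas the earlier steps each exchanged the whole group on the saturated chain carbon. The low number of compound 3 therefore cannot be credited to the pyrazole ring alone, since 4-(1-methylpiperidin-4-yl)-1H-pyrazol-1-yl gives no separation beyond the scatter from either of the other two groups on that chain carbon, with a 1.2-fold higher number from compound 2 to compound 4 (0.09 log units; within the scatter) and a 2.0-fold lower number from compound 1 to compound 4 (0.30 log units; within the scatter). No supporting data are available to explain the step from chloro to 1-methylpiperidin-4-yl.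

Still open, going by these compounds, is whether the six-membered ring or its nitrogen accounts for the higher number, as the entering group brings both in a single change. A cyclohexyl group on the same aromatic carbon would separate these two features, while bromo or methyl there would show how specific the number of compound 3 is to chloro.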